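Replacing 4-hydroxyphenyl with 3-chloro-5-fluorophenyl on the shared core

The compounds below may be only part of what the source reports. "The series", "measured", "known", "first", "only" and "open" are said of these compounds alone.

Going by the values given here, only two compounds have been measured so far in an ADME assay on A549 cells (Homo sapiens) for cytotoxicity, read by resazurin assay, with a stated time of 48 h; a higher number here means that more compound is tolerated, a lower number that less compound is tolerated. Compound 1 `CCCNc1ccc(NC(=O)c2cc(Cl)ccc2O)c(Cl)c1` gives 22500 nM, and compound 2 `O=C(Nc1ccc(NCc2ccc(O)cc2)cc1Cl)c1cc(Cl)ccc1O` gives 116000 nM, the higher of the two numbers, so compound 2 is the better tolerated.

The next compound, compound 3 `O=C(Nc1ccc(NCc2cc(F)cc(Cl)c2)cc1Cl)c1cc(Cl)ccc1O`, keeps the shared core and changes one group: 3-chloro-5-fluorophenyl in place of 4-hydroxyphenyl on a saturated chain carbon bound to a nitrogen on an aromatic ring. In plain words, 3-chloro-5-fluorophenyl stands in place of 4-hydroxyphenyl on a saturated chain carbon bound to a nitrogen on an aromatic ring. Among the compounds with values here, one measured step bears on this: a 5.2-fold higher number from compound 1 to compound 2 (0.71 log units; beyond the scatter), seen when 4-hydroxyphenyl took the place of ethyl on that same carbon. Within the data shown here, this is thin evidence, and no measured compound carries the 3-chloro-5-fluorophenyl group. Still, compound 1 also lacks 4-hydroxyphenyl and sits at 22500 nM, so a step of similar size toward a lower number is expected in this assay. The expected change is a 3.9-fold lower number from compound 2 to compound 3 (0.59 log units; beyond the scatter). For compound 3 the estimate is 30000 nM, with an expected range of 9000 nM to 100000 nM.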

Compound 3, half-maximal cytotoxic concentration: 11100 nM
Compound 3: middle estimate off by 2.7-fold (0.43 log units), on the high side; measured number inside the range.
By their numbers in this assay, from the lowest: compound 3; then compound 1; then compound 2.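

Changing the group on this saturated chain carbon can move the number a long way in either direction: in this assay there is a 10-fold lower number from compound 2 to compound 3 (1.02 log units; beyond the scatter). The ethyl group of compound 1 no longer marks the low end, since there is also a 2.0-fold lower number from compound 1 to compound 3 (0.31 log units; beyond the scatter), whereas the earlier step, a 5.2-fold higher number from compound 1 to compound 2 (0.71 log units; beyond the scatter), went the other way. Both 4-hydroxyphenyl and 3-chloro-5-fluorophenyl are six-membered aromatic rings of carbon only, yet they fall on opposite sides of ethyl, so having an aromatic ring here does not by itself set the direction, and nothing shown explains the gap between them.

The compounds shown swap the hydroxyl group and the two halogens together, so they cannot tell whether losing the one or gaining the others accounts for the drop; plain phenyl, 3-chlorophenyl or 3-fluorophenyl would separate these. From the compounds shown here alone, it also remains open where other groups on this ring, such as a carboxylic acid, an amine or a methoxy group, would fall relative to compound 2 and compound 3.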